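The source may report more compounds than this note shows. Statements on the series, on what has been measured and on what is new or still open speak of the compounds shown alone.

Measured compounds in a functional assay on HeLa cells (Homo sapiens) for cytotoxicity, read by MTT assay, with a stated time of 24 h; on this read-out lower numbers stand for stronger inhibition and higher numbers for weaker inhibition:
Compound 1 `Cc1cc(O)c(C(=O)/C=C/c2ccc(F)cc2)c(-c2ccccc2)c1C(=O)/C=C/c1ccc(F)cc1`: 30000 nM
Compound 2 `Cc1cc(O)c(C(=O)/C=C/c2ccc(F)cc2)c(-c2ccc(Br)cc2)c1C(=O)/C=C/c1ccc(F)cc1`: "not active" (no number reported)
Compound 3 `COc1ccc(/C=C/C(=O)c2c(C)cc(O)c(C(=O)/C=C/c3ccc(OC)cc3)c2-c2ccc(Br)cc2)cc1`: "not active" (no number reported)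

Compound 2 stands without a number: in this assay compound 2 is recorded as "not active" (no number reported), and compound 3 shares that fate with "not active" (no number reported). Only compound 1 gives a figure, and at 30000 nM it is a weak one. Compound 4 `Cc1cc(O)c(C(=O)/C=C/c2ccc(F)cc2)c(-c2ccc(OCc3ccccc3)cc2)c1C(=O)/C=C/c1ccc(F)cc1` differs from compound 2 by benzyloxy in place of bromo on an aromatic carbon. Among the measured compounds shown here, with no comparable step among the measured compounds, the size of this change cannot be anticipated from data; the expectation is no shift beyond the scatter, with a real chance that again only a limit is reported. Compound 4 is therefore estimated at 40000 nM in this assay, within 10000 nM to 150000 nM.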

Compound 4, half-maximal inhibitory concentration: 25000 nM
Beside the measured number, compound 4's estimate is 1.6-fold (0.20 log units) above it, within the range that was stated.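

Benzyloxy in place of hydrogen on an aromatic carbon gives a 1.2-fold lower number from compound 1 to compound 4 (0.08 log units; within the scatter) in this assay, so a ring-bearing group at this position leaves the number within the scatter. With bromo at the same position, compound 2 is recorded as "not active" (no number reported), so that this step cannot be read as a size, and compound 4 still gives a figure. No measured evidence accounts for this contrast. On these data alone, whether an amine or a carboxylic acid at this position would give a stronger number remains open.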